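The source may hold more compounds than are shown below. What is called first, only, known or untested is meant among the compounds shown, and "the series" means these compounds.

Compound 1 `CC(C)S(=O)(=O)N1Cc2nc(C#Cc3ccccc3)sc2C1`: in an assay on HEK293 cells for positive allosteric modulation of metabotropic glutamate receptor 5 (Homo sapiens), read by FLIPR, with a stated time of 1 h (a higher number here means that more compound is needed for the effect, a lower number that less compound is needed), compound 1 gives > 10000 nM, which is a limit of the assay and not a number.
Compound 2 `O=S(=O)(C1CCCCC1)N1Cc2nc(C#Cc3ccccc3)sc2C1`: in this assay compound 2 gives 150 nM.

Compound 2 thus holds the only number shown in this assay; the other value is a limit. Within the data shown here, the single measured step is an at least 66-fold lower number from compound 1 to compound 2 (1.82 log units; beyond the scatter), and it starts from the limit of > 10000 nM in this assay, at which 1 of the 2 values shown sits. Compound 3 `O=S(=O)(N1CCCCC1)N1Cc2nc(C#Cc3ccccc3)sc2C1` differs from compound 2 by piperidin-1-yl in place of cyclohexyl on a sulfonyl sulfur. Among the measured compounds shown here, this keeps the six-membered ring that the measured step introduced, and no measured step bears on the ring nitrogen itself. Compound 3 is therefore expected to stay close to compound 2, with an expected step of a 1.7-fold higher number from compound 2 to compound 3 (0.22 log units; within the scatter) in this assay, giving an estimate of 250 nM (range 80 nM to 1000 nM).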

Compound 3, half-maximal effective concentration: 250 nM
For compound 3 middle estimate and measured number coincide at the digits printed, within the range that was stated.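

With a 1.7-fold higher number from compound 2 to compound 3 (0.22 log units; within the scatter) in this assay, piperidin-1-yl serves on the sulfonyl sulfur as well as cyclohexyl does, so this position accepts a ring attached through nitrogen as well as one attached through carbon. Isopropyl now stands apart from two six-membered rings rather than one, with an at least 40-fold lower number from compound 1 to compound 3 (1.60 log units; beyond the scatter) in this assay. On these data alone, the size of that step remains open-ended, as compound 1 gives a limit of the assay and not a number: the limit of > 10000 nM in this assay, at which 1 of the 3 values shown sits. As far as these compounds go, whether morpholin-4-yl, cyclopentyl or a longer chain on the sulfonyl sulfur would give similar numbers remains open.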